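Series notes: amide substituent change on the shared core

The compounds below may be only part of what the source reports. "The series", "measured", "known", "first", "only" and "open" are said of these compounds alone.

Compound 1, `CC(C)=CCCC1=CC[C@H](C(=O)Nc2ccc(O)cc2)[C@@H](c2ccccc2)C1`, compound 2, `COc1ccc(NC(=O)[C@H]2CC=C(CCC=C(C)C)C[C@@H]2c2ccccc2)cc1`, and compound 3, `COc1ccc(NC(=O)[C@@H]2CC=C(CCC=C(C)C)C[C@H]2c2ccccc2)cc1`, share one core and differ by a methyl in place of hydrogen on an oxygen on an aromatic ring or only in configuration as drawn. In an assay on isolated protein for inhibition of Apoptosis regulator Bcl-2 (Homo sapiens), read by fluorescence polarization, with stated times of 5 min and 10 min (a lower number here means a stronger inhibitor, a higher number a weaker inhibitor), compound 1 gives only a limit, > 23000 nM. In this assay compound 2 also gives only a limit, > 23000 nM. Compound 3 likewise gives only a limit in this assay, > 23000 nM. The step that the two limits leave unreadable from compound 1 to compound 2 and the step that the two limits leave unreadable from compound 2 to compound 3 are unreadable because of the limit of > 23000 nM in this assay, at which 3 of the 3 values shown sit; for the second step the fact that compounds 2 and 3 differ only in the configuration as drawn adds that the two compounds share all atoms and bonds. Compound 3 thus stands at a limit, and no order among the three compounds can be read.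

Compound 4, `COC(=O)CCNC(=O)[C@@H]1CC=C(CCC=C(C)C)C[C@H]1c1ccccc1`, differs from compound 3 by 2-(methoxycarbonyl)ethyl in place of 4-methoxyphenyl on an amide-type nitrogen. Among the measured compounds shown here, no measured step touches this position with a readable size, and every value so far sits at the same limit. For compound 4 a value at or near that limit is expected, with a step that the limit leaves unreadable from compound 3 to compound 4 taken as no readable change. The estimate for compound 4 in this assay is 30000 nM, within 8000 nM to 120000 nM, most likely again reported only as a limit.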

Compound 4, inhibition constant: > 23000 nM
Compound 4 gave a limit, no number; the forecaster's own chance of this, stated with the estimate: 85%; the middle value lies beyond the limit too.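

In this assay compound 4 gives only a limit, > 23000 nM. Among the compounds shown here, no step from compound 3 to compound 4 can be read, and the series gains no new step, because every value shown stands at this limit: the limit of > 23000 nM in this assay, at which 4 of the 4 values shown sit. The compounds shown leave open whether any amide substituent or configuration on the shared core gives a measurable value in this assay.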